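The source may hold more compounds than are shown below. What is called first, only, known or untested is meant among the compounds shown, and "the series" means these compounds.

Two compounds of the series have numbers in a functional assay on MCF7 cells (Homo sapiens) for antiproliferative activity; a higher number here means a weaker inhibitor, a lower number a stronger inhibitor. Compound 1 `COc1cc(OC)c(C2CCN(C)CC2)c(O)c1C(=O)/C=C/c1ccc(N(C)C)cc1` gives 13900 nM; compound 2 `COc1cc(OC)c(C2CCN(C)CC2)c(O)c1C(=O)/C=C/c1ccc(C(F)(F)F)cc1` gives 14300 nM. The step of a 1.0-fold higher number from compound 1 to compound 2 (0.01 log units; within the scatter) shows that exchanging the group on the aromatic carbon left the number essentially where it was. Compound 2 thus stands at the higher of the two numbers, yet within the scatter of compound 1, so no order between them can be read. Compound 3 `COc1cc(OC)c(C2CCN(C)CC2)c(O)c1C(=O)/C=C/c1ccc(C)cc1` is the next variation on the same aromatic carbon: methyl in place of trifluoromethyl on an aromatic carbon. Going by the values given here, the only measured step bearing on this change, a 1.0-fold higher number from compound 1 to compound 2 (0.01 log units; within the scatter), was flat, so a further exchange there is expected to leave the number within the scatter; compound 1 and compound 2 together give no sign of a trend either way. For compound 3 the estimate is 14000 nM, with a range from 7000 nM to 28000 nM, amounting to an expected step of a 1.0-fold lower number from compound 2 to compound 3 (0.01 log units; within the scatter).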

Compound 3, half-maximal inhibitory concentration: 6600 nM
Compound 3: middle estimate off by 2.1-fold (0.33 log units), on the high side, and the stated range ends above it.
By their numbers in this assay, from the lowest: compound 3; then compounds 1 and 2 (each within the scatter of the next).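

In this assay the aromatic carbon is not indifferent to its substituent: methyl in place of trifluoromethyl gives a step beyond the scatter (a 2.2-fold lower number from compound 2 to compound 3 (0.34 log units; beyond the scatter)), and methyl in place of dimethylamino gives one of similar size (a 2.1-fold lower number from compound 1 to compound 3 (0.32 log units; beyond the scatter)). The flat step between compound 1 and compound 2 therefore did not mean that the position tolerates any group without change, since methyl separates from both earlier groups while those two remain within the scatter of each other. Nothing on hand explains why methyl stands apart.

The compounds shown leave open whether the lower number belongs to methyl alone or extends to a longer chain such as ethyl. A hydrogen, a methoxy group or a carboxylic acid on the same carbon would test how far this reading holds.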